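The source may hold more compounds than are shown below. What is called first, only, known or untested is meant among the compounds shown, and "the series" means these compounds.

Measured compounds:
- Compound 1 `COC(=O)c1sc2cc(C#Cc3ccc(F)cc3)cnc2c1N` gives 24000 nM in a functional assay on NCI-H460 cells (Homo sapiens) for inhibition, read by sulforhodamine B assay, with a stated time of 48 h; on this read-out lower numbers stand for stronger inhibition of growth and higher numbers for weaker inhibition of growth
- Compound 2 `COC(=O)c1sc2cc(C#Cc3ccccc3N)cnc2c1N` gives 5700 nM in this assay
- Compound 3 `COC(=O)c1sc2cc(C#Cc3ccc(N(C)C)cc3)cnc2c1N` gives 16600 nM in this assay

Compound 3 stands second highest of the three measured compounds; its number is within the scatter of compound 1 and separated beyond the scatter from compound 2. Compound 4 `COC(=O)c1sc2cc(C#Cc3ccccc3)cnc2c1N` is not yet measured. The change from compound 3 to it is hydrogen in place of dimethylamino on an aromatic carbon.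

Among the measured compounds shown here, the step that bears most on this is the one from compound 1 to compound 3, which swapped the group at the same place and gave a 1.4-fold lower number from compound 1 to compound 3 (0.16 log units; within the scatter). The step of a 4.2-fold lower number from compound 1 to compound 2 (0.62 log units; beyond the scatter) changed the ring itself and so speaks less directly. Since an exchange at this place hardly moved the number, little movement beyond the scatter is expected in this assay for the change to hydrogen, in either direction.

Compound 4 is therefore expected to give about 18000 nM, between 7000 nM and 45000 nM, an estimated step of a 1.1-fold higher number from compound 3 to compound 4 (0.04 log units; within the scatter).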

Compound 4, concentration for 50% growth inhibition: > 150000 nM
Compound 4 ended at the assay's limit; the forecaster's own chance of this, stated with the estimate: 10%; middle value at least 8.3-fold (0.92 log units) away from the limit.
By their numbers in this assay, from the lowest: compound 2; then compounds 3 and 1 (each within the scatter of the next). At a limit, above all of these: compound 4.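

Compound 4, which carries only hydrogen on this aromatic carbon, reached a limit of this assay rather than giving a number: the limit of > 150000 nM in this assay, at which 1 of the 4 values shown sits.

Each substituted compound gives a lower number than this unsubstituted one, as seen in an at least 9.0-fold higher number from compound 3 to compound 4 (0.95 log units; beyond the scatter), an at least 6.2-fold higher number from compound 1 to compound 4 (0.79 log units; beyond the scatter) and an at least 26-fold higher number from compound 2 to compound 4 (1.42 log units; beyond the scatter). Swapping fluoro for dimethylamino had barely moved the number, so the earlier compounds could not show what this comparison shows: in these compounds, having a group on the phenyl ring matters far more than which of the three groups it is, and no compound shown goes against this.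

As far as these compounds go, how far compound 4 lies past the limit remains open, so these steps give only minimum sizes. Also open, from the compounds shown here alone, is whether a methyl group or a carboxylic acid on the same aromatic carbon would lower the number as well.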